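Chloroacetamide series on the shared core: next analogue

This account rests on a few compounds, and the source may have more. Where it says the series, first, only, none or still open, it means among the compounds named here.

Measured so far:
compound 1 `Cn1c(-c2ccc(NC(=O)CCl)cc2)nc(-c2ccccc2)c1-c1ccccc1` — 28.7 ug/mL
compound 2 `Cc1nnc(SCC(=O)Nc2ccc(-c3nc(-c4ccccc4)c(-c4ccccc4)n3C)cc2)s1` — 2.7 ug/mL

In a functional assay on HT-29 cells (Homo sapiens) for cytotoxicity, read by MTT assay, with a stated time of 24 h (a lower number here means a stronger inhibitor, a higher number a weaker inhibitor), compound 2 holds the lowest of the two numbers; the nearest is compound 1, and the step of an 11-fold lower number from compound 1 to compound 2 (1.03 log units; beyond the scatter) lies beyond the scatter. Compound 3 `CCN1CCN(CC(=O)Nc2ccc(-c3nc(-c4ccccc4)c(-c4ccccc4)n3C)cc2)CC1` is the next analogue. It differs from compound 2 as 4-ethylpiperazin-1-yl in place of (5-methyl-1,3,4-thiadiazol-2-yl)sulfanyl on a saturated chain carbon bound to a carbonyl carbon. Among the measured compounds shown here, no measured step covers this exchange; the one step on record, an 11-fold lower number from compound 1 to compound 2 (1.03 log units; beyond the scatter), exchanges a chloro at the same place and is large, so a change at this position can move this assay considerably, in either direction. Without a closer precedent, compound 3 is expected to land between the two measured numbers, nearer compound 2, at an estimated 8 ug/mL (range 2.5 ug/mL to 30 ug/mL), meaning an expected step of a 3.0-fold higher number from compound 2 to compound 3 (0.47 log units; beyond the scatter).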

Compound 3, half-maximal inhibitory concentration: 75 ug/mL
For compound 3 the middle estimate is 9.4-fold (0.97 log units) below the measured one; measured number outside the range, above it.
By their numbers in this assay, from the lowest: compound 2; then compound 1; then compound 3.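

In this assay, the saturated chain carbon bound to a carbonyl carbon now shows changes in both directions: 4-ethylpiperazin-1-yl gives a 28-fold higher number from compound 2 to compound 3 (1.44 log units; beyond the scatter) and a 2.6-fold higher number from compound 1 to compound 3 (0.42 log units; beyond the scatter). The number for this group therefore lies above those for both chloro and (5-methyl-1,3,4-thiadiazol-2-yl)sulfanyl, and of the two replacements for chloro only the latter lowers it. No available evidence accounts for these steps.

From the compounds shown here alone, it remains open whether the sulfur link or the ring goes with the low number of compound 2; a phenylsulfanyl or morpholin-4-yl group at this place could help separate them.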